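The compounds below may be only part of what the source reports. "The series", "measured", "known", "first", "only" and "open" are said of these compounds alone.

In an ADME assay on CHO cells (Cricetulus griseus) for cytotoxicity, read by LDH release (on this read-out higher numbers stand for weaker inhibition and lower numbers for stronger inhibition), compound 1 (`CC(Oc1ccc(Cl)cc1Cl)C(=O)NCc1ccc(Cl)cc1`) gives 39000 nM. Among the compounds with values here, its only measured neighbour, compound 2 (`Cc1cccc(CNC(=O)C(C)Oc2ccc(Cl)cc2Cl)c1`), gives 45000 nM, so the two cannot be told apart within the usual scatter of repeat measurements. Compound 3 (`COc1ccc(CNC(=O)C(C)Oc2ccc(Cl)cc2Cl)cc1`) carries methoxy in place of chloro on an aromatic carbon. Within the data shown here, the one measured step that bears on this also takes away the chloro group, and it is small: a 1.2-fold higher number from compound 1 to compound 2 (0.06 log units; within the scatter). No shift beyond the scatter is therefore expected in this assay. The expected step is a 1.1-fold higher number from compound 1 to compound 3 (0.03 log units; within the scatter). For compound 3 the estimated value is 42000 nM, with an expected range of 20000 nM to 85000 nM.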

Compound 3, half-maximal inhibitory concentration: 71000 nM
Estimate against measurement, compound 3: 1.7-fold (0.23 log units) below, and the stated range covers the measured number.
By their numbers in this assay, from the lowest: compounds 1, 2 and 3 (each within the scatter of the next).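

In this assay the swap of methoxy for chloro on an aromatic carbon, para to a large group, gives a 1.8-fold higher number from compound 1 to compound 3 (0.26 log units; within the scatter) and so stays inside the scatter. This position therefore tolerates a group with one more heavy atom and a hydrogen-bond acceptor without a readable shift in this read-out. Nothing measured here accounts for the size of this step. Still open, on these data alone, is whether an amine or a carboxylic acid on this aromatic carbon would give a step beyond the scatter.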